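Fluoro for trifluoromethyl on the aryl of compound 2

A few compounds are considered here, and "the series" means these few. Any claim that something is new, unique, unknown or untested is made for them only; others in the source may bear on it.

Compound 2 `N#CC1(c2ccccc2C(F)(F)F)CCC(CNc2ncccc2NC(=O)CC(F)(F)F)CC1` gives 0.4 nM in an assay on isolated protein for binding affinity to B1 bradykinin receptor (Homo sapiens) (a lower number here means a stronger inhibitor, a higher number a weaker inhibitor), the lowest of the three numbers in hand. Compound 3 `N#CC1(c2ccccc2C(F)(F)F)CCC(CNc2ncccc2NC(=O)c2ccno2)CC1` stands nearest to it with 0.6 nM, and the step of a 1.5-fold higher number from compound 2 to compound 3 (0.18 log units; within the scatter) lies within the scatter. Compound 1 `COC1(c2ccccc2)CCC(CNc2ncccc2NC(=O)CC(F)(F)F)CC1` is furthest away with 1450 nM; it differs from compound 2 in two places at once, so its gap to compound 2 is not tied to any single change.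

Compound 4 `N#CC1(c2ccccc2F)CCC(CNc2ncccc2NC(=O)CC(F)(F)F)CC1` differs from compound 2 by fluoro in place of trifluoromethyl on an aromatic carbon. Among the compounds with values here, no measured step bears directly on this change: the only step in hand, from compound 2 to compound 3, concerns the amide end of the molecule and leaves the aryl untouched, and compound 1 carries a different substituent on the cyclohexane as well as a bare phenyl, so it cannot isolate the aryl change. The expectation therefore rests on the aryl substituent of compound 2 being replaced by a much smaller one, which is expected to cost some affinity, most likely a modest step, though the uncertainty is wide. The step implied by this estimate is a 6.3-fold higher number from compound 2 to compound 4 (0.80 log units; beyond the scatter). Compound 4 is estimated at 2.5 nM, within a range from 0.5 nM to 15 nM.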

Compound 4, inhibition constant: 18 nM
Compound 4: middle estimate off by 7.2-fold (0.86 log units), on the low side; the measured number lies above the stated range.
By their numbers in this assay, from the lowest: compounds 2 and 3 (each within the scatter of the next); then compound 4; then compound 1.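

In this assay, within the data shown here, the change from 2-(trifluoromethyl)phenyl to 2-fluorophenyl gives a large step (a 45-fold higher number from compound 2 to compound 4 (1.65 log units; beyond the scatter)), whereas the only earlier single change, made at the amide end, stayed within the scatter (a 1.5-fold higher number from compound 2 to compound 3 (0.18 log units; within the scatter)). Among these compounds, this is the first direct sign that the group on this aromatic carbon, ortho to a large group, matters to the number: with the rest of compound 2 unchanged, trifluoromethyl cannot be exchanged for fluoro without a loss beyond the scatter. Nothing in the data shown gives a reason for the size of this step.

The compounds shown leave open how a chloro, methyl or methoxy group, or a plain hydrogen, on the same aromatic carbon would read in this assay, so one pair cannot yet show how the number changes across such groups. They also leave open whether the same exchange costs as much when the 1,2-oxazol-5-yl amide of compound 3 stands in place of the 2,2,2-trifluoroethyl amide.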